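Replacing 4-fluorophenyl with difluoromethyl on the shared core

The source may hold more compounds than are shown below. What is called first, only, known or untested is meant among the compounds shown, and "the series" means these compounds.

- compound 1 `Cc1noc(C)c1[C@@H]1C[C@@](C)(c2ccc(F)cc2F)N=C(N)S1` shows 72% remaining
- compound 2 `Cc1noc(-c2ccccc2)c1[C@@H]1C[C@@](C)(c2ccc(F)cc2F)N=C(N)S1` shows 6% remaining
- compound 3 `Cc1noc(-c2ccc(F)cc2)c1[C@@H]1C[C@@](C)(c2ccc(F)cc2F)N=C(N)S1` shows 53% remaining

All three values come from an ADME assay on microsomes from liver (Mus musculus) for metabolic stability, with a stated time of 10 min, tested at 0.5 uM (on this read-out higher numbers stand for a more stable compound and lower numbers for a less stable compound), and the compounds differ only in one group. Compound 3 stands second highest of the three. Two steps fix its place: a number 19 percentage points lower from compound 1 to compound 3 (beyond the scatter) and a number 47 percentage points higher from compound 2 to compound 3 (beyond the scatter).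

The next compound is compound 4 `Cc1noc(C(F)F)c1[C@@H]1C[C@@](C)(c2ccc(F)cc2F)N=C(N)S1`, which makes a single change to compound 3: difluoromethyl in place of 4-fluorophenyl on an aromatic carbon. In words, this is difluoromethyl in place of 4-fluorophenyl on an aromatic carbon.

Among the compounds with values here, no measured compound carries difluoromethyl, so the guide has to be indirect. Within the data shown here, the closest comparison is compound 1, the only measured compound without a ring at that place, and it has the highest value at 72% so far. Both ring-bearing compounds fall short of it, as a number 66 percentage points lower from compound 1 to compound 2 (beyond the scatter) and the smaller step to compound 3 show. Read backwards, a number 19 percentage points lower from compound 1 to compound 3 (beyond the scatter) suggests a modest rise once the ring leaves, although difluoromethyl is not methyl and the range must stay wide.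

The expected change is a number 15 percentage points higher from compound 3 to compound 4 (beyond the scatter) in size and direction. For compound 4 the estimated value is 68%, with an expected range from 45% to 88%.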

Compound 4, percent of the compound remaining: 59%
For compound 4 the middle estimate is 9 percentage points above the measured one; low and high end bracket the measured number.
By their numbers in this assay, from the lowest: compound 2; then compounds 3 and 4 (each within the scatter of the next); then compound 1.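

In this assay, taking away the aromatic ring at this place does not by itself change the picture: the step is a number 6 percentage points higher from compound 3 to compound 4 (within the scatter), so difluoromethyl and 4-fluorophenyl cannot be told apart here, even though they differ greatly in size and only one of them carries a ring. The plain phenyl compound stands well apart from the difluoromethyl compound, with a number 53 percentage points higher from compound 2 to compound 4 (beyond the scatter), while difluoromethyl does not reach the small methyl group, with a number 13 percentage points lower from compound 1 to compound 4 (beyond the scatter), so having a ring or not having one does not alone sort these four compounds. Nothing measured here explains these differences.

The compounds shown leave open how an amine, a carboxylic acid or a longer chain would fare on this aromatic carbon next to the ring oxygen, and whether trifluoromethyl would read closer to methyl or to difluoromethyl. They also leave open whether these same steps would hold on a different core.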